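The source may hold more compounds than are shown below. What is called first, only, known or untested is meant among the compounds shown, and "the series" means these compounds.

Working notes on the series, read in a functional assay on the whole organism with Rattus norvegicus as the target; a higher number here means that more compound is needed for the effect, a lower number that less compound is needed. Compound 3 `CCOCCOC(=O)C(=O)Nc1nc(-c2cc(OCc3ccccc3)no2)cs1` gives only a limit, > 100 mg/kg. Compound 1 `CCOCCOC(=O)C(=O)Nc1nc(-c2cc(Cl)no2)cs1` also gives only a limit, > 30 mg/kg. Compound 2 `CCOCCOC(=O)C(=O)Nc1nc(-c2cc(OC)no2)cs1` gives a true number, 11 mg/kg.

Compound 3 therefore stands apart from compound 2, with an at least 9.0-fold higher number from compound 2 to compound 3 (0.95 log units; beyond the scatter). Against the other limit there is a step that the two limits leave unreadable from compound 1 to compound 3, so no order can be drawn there.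

The next change leads to compound 4 `CCOCCOC(=O)C(=O)Nc1nc(-c2cc(-c3c(F)cccc3Cl)no2)cs1`: 2-chloro-6-fluorophenyl in place of benzyloxy on an aromatic carbon, (2-chloro-6-fluorophenyl in place of benzyloxy on an aromatic carbon). The same place carries the measured steps. Besides the step above, there is an at least 2.7-fold lower number from compound 1 to compound 2 (0.43 log units; beyond the scatter). Both show that this place can move the read-out beyond the scatter, but neither tests a phenyl ring bound directly to the ring carbon.

The direction is therefore weakly held, and a modest fall in the number is expected, with a further limit quite possible. The estimated step is an at least 2.5-fold lower number from compound 3 to compound 4 (0.39 log units; beyond the scatter). For compound 4 the expected value is 40 mg/kg, with an estimated range of 12 mg/kg to 130 mg/kg.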

Compound 4, dose for half-maximal effect: > 30 mg/kg
Compound 4 gave a limit, no number (the forecaster's own chance of this, stated with the estimate: 45%); the middle value does not contradict the limit.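

In this assay, 2-chloro-6-fluorophenyl in place of methoxy on this aromatic carbon gives an at least 2.7-fold higher number from compound 2 to compound 4 (0.43 log units; beyond the scatter). Among these compounds, this is the first test of a phenyl ring bound directly to the ring carbon, and like chloro and benzyloxy it yields only a limit, so methoxy remains the only group at this position with a true number. The steps from compound 1 and from compound 3 to compound 4 cannot be read, and compound 4 shares its limit with another compound of the series: the limit of > 30 mg/kg in this assay, at which 2 of the 4 values shown sit.

The share of the chloro and fluoro substituents cannot be separated from that of the phenyl ring itself, and an unsubstituted phenyl would be needed to do so. From the compounds shown here alone, whether an amine or an ethoxy group on this carbon would give a true number, and how it would compare with compound 2, stays open.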